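Extending a Methyl to an Ethyl on the Urea Phenyl

The source may report more compounds than this note shows. Statements on the series, on what has been measured and on what is new or still open speak of the compounds shown alone.

Three ureas built on one shared core have been measured in a functional assay on HepG2 cells (Homo sapiens) for antiproliferative activity, read by MTT assay, with a stated time of 48 h; a higher number here means a weaker inhibitor, a lower number a stronger inhibitor. Compound 1 `O=C(Nc1cccc(CNc2nccnc2Cl)c1)Nc1ccccc1Cl` gives 8560 nM, compound 2 `O=C(Nc1cccc(CNc2nccnc2Cl)c1)Nc1ccccc1F` gives 10500 nM, and compound 3 `Cc1ccccc1NC(=O)Nc1cccc(CNc2nccnc2Cl)c1` gives 15300 nM. Compound 3 carries the highest of the three numbers, but its gaps to the others are small: a 1.8-fold higher number from compound 1 to compound 3 (0.25 log units; within the scatter) and a 1.5-fold higher number from compound 2 to compound 3 (0.16 log units; within the scatter) both lie within the scatter, as does a 1.2-fold higher number from compound 1 to compound 2 (0.09 log units; within the scatter). The three compounds therefore cannot be ranked in this assay.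

Compound 4 `CCc1ccccc1NC(=O)Nc1cccc(CNc2nccnc2Cl)c1` differs from compound 3 by methyl in place of hydrogen on a saturated chain carbon bound to an aromatic carbon, that is methyl to ethyl. Among the measured compounds shown here, no measured step is of this kind, but the steps that do exist all swap one small group for another at the same aromatic carbon and none moves the number beyond the scatter. A small group growing by one carbon at the same place is expected to behave alike, so compound 4 is estimated at 16000 nM, between 7000 nM and 40000 nM, an expected step of a 1.0-fold higher number from compound 3 to compound 4 (0.02 log units; within the scatter) that stays within the scatter.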

Compound 4, half-maximal inhibitory concentration: 7860 nM
Compound 4: the middle estimate sits 2.0-fold (0.31 log units) above what was measured; measured number inside the range.
By their numbers in this assay, from the lowest: compounds 4, 1, 2 and 3 (each within the scatter of the next).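

In this assay, among the compounds shown here, methyl to ethyl reads as a 1.9-fold lower number from compound 3 to compound 4 (0.29 log units; within the scatter) and stays within the scatter, the first step here that lengthens a chain rather than swapping one small group for another. Set against the two halogens on an aromatic carbon, ethyl gives a 1.3-fold lower number from compound 2 to compound 4 (0.13 log units; within the scatter) and a 1.1-fold lower number from compound 1 to compound 4 (0.04 log units; within the scatter) with no step beyond the scatter, so chloro, fluoro, methyl and ethyl at this position cannot be ranked. Nothing available offers an explanation for these numbers.

Still open, on these data alone, is whether a longer chain such as propyl, or a different group such as methoxy or a carboxylic acid, would move the number beyond the scatter at this position. Also open, as far as these compounds go, is how the urea phenyl would read with hydrogen in place of these groups.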